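The compounds below may be only part of what the source reports. "The series", "measured", "known", "first", "only" and "open" are said of these compounds alone.

Compound 1 `COc1ccc(-c2ccc(-c3ccc(-c4nc5cc(C)ccc5[nH]4)cc3)cc2)cc1OC`: 2120 nM
Compound 2 `COc1ccc(-c2ccc(-c3ccc(-c4nc5c(O)cccc5[nH]4)cc3)cc2)cc1OC`: 2210 nM
Compound 3 `Cc1ccc2[nH]c(-c3ccc(-c4ccc(-c5ccc(C(F)(F)F)cc5)cc4)cc3)nc2c1`: not yet measured

Within the data shown here, in a functional assay on HOP-62 cells (Homo sapiens) for inhibition, read by sulforhodamine B assay (on this read-out higher numbers stand for weaker inhibition of growth and lower numbers for stronger inhibition of growth), compound 1 gives 2120 nM and has compound 2 as its only neighbour, level with it: a 1.0-fold higher number from compound 1 to compound 2 (0.02 log units; within the scatter). The change to compound 3 is 4-(trifluoromethyl)phenyl in place of 3,4-dimethoxyphenyl on an aromatic carbon. Among the measured compounds shown here, the one measured step concerns a different group, so it does not test this change, and no size or direction beyond the scatter can be expected from it. The expected step is a 1.2-fold higher number from compound 1 to compound 3 (0.07 log units; within the scatter). For compound 3 the estimate in this assay is 2500 nM, with an expected range of 800 nM to 8000 nM.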

Compound 3, concentration for 50% growth inhibition: 24200 nM
Compound 3: the middle estimate sits 9.7-fold (0.99 log units) below what was measured, outside the stated range (above it).
By their numbers in this assay, from the lowest: compounds 1 and 2 (each within the scatter of the next); then compound 3.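

At this place, on an aromatic carbon para to a large group, the series responds strongly in this assay: 4-(trifluoromethyl)phenyl in place of 3,4-dimethoxyphenyl gives an 11-fold higher number from compound 1 to compound 3 (1.06 log units; beyond the scatter), which means weaker inhibition of growth. The earlier pair showed no such sensitivity, but it varied a different group. No measurement on hand accounts for this step.

As far as these compounds go, it remains open whether the step follows from losing the methoxy groups or from gaining the trifluoromethyl group. From the compounds shown here alone, whether a single methoxy group, a hydroxyl or an amine here would keep the level of compound 1 also remains open.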